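A few compounds are considered here, and "the series" means these few. Any claim that something is new, unique, unknown or untested is made for them only; others in the source may bear on it.

Compound 1 `O=C1C(NC2CCCC2)=CC(=O)c2c1nc1n2[C@H]2OC[C@@H](O)[C@H]2OC1` and compound 3 `O=C1C=C(NC2CCCC2)C(=O)c2c1nc1n2[C@H]2OC[C@@H](O)[C@H]2OC1` are built from the same atoms joined differently; how the two cores differ is not broken down here. In a functional assay on MGC-803 cells (Homo sapiens) for inhibition, read by sulforhodamine B assay (on this read-out lower numbers stand for stronger inhibition and higher numbers for weaker inhibition), compound 1 reaches only the limit > 16000 nM. Compound 3 likewise gives only the limit > 8000 nM in this assay. Compound 2 `COc1ccccc1NC1=CC(=O)c2c(nc3n2[C@H]2OC[C@@H](O)[C@H]2OC3)C1=O` carries the change 2-methoxyphenyl in place of cyclopentyl on an amine nitrogen on the core of compound 1; in this assay compound 2 gives 1670 nM, a step of an at least 9.5-fold lower number from compound 1 to compound 2 (0.98 log units; beyond the scatter). Compound 4 `COc1ccccc1NC1=CC(=O)c2nc3n(c2C1=O)[C@H]1OC[C@@H](O)[C@H]1OC3` carries the same change, (2-methoxyphenyl in place of cyclopentyl on an amine nitrogen), on the core of compound 3; the surroundings of the amine nitrogen read the same word for word in both cases. A step of similar size is expected for an at least 6.6-fold lower number from compound 3 to compound 4 (0.82 log units; beyond the scatter), resting on the measured step of an at least 9.5-fold lower number from compound 1 to compound 2 (0.98 log units; beyond the scatter). Since compound 3 starts from a limit, the absolute level is uncertain. Compound 4 is estimated at 1200 nM, between 400 nM and 5000 nM.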

Compound 4, half-maximal inhibitory concentration: 1630 nM
Beside the measured number, compound 4's estimate is 1.4-fold (0.13 log units) below it; low and high end bracket the measured number.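

In this assay, the change from cyclopentylamino to (2-methoxyphenyl)amino gives, on the second core, an at least 4.9-fold lower number from compound 3 to compound 4 (0.69 log units; beyond the scatter). Set beside the earlier step, the lower number carries over from one core to the other, but the size of the step on each core remains unsettled: the same change on two cores in this assay, an at least 9.5-fold lower number (0.98 log units; beyond the scatter) from compound 1 to compound 2 and an at least 4.9-fold lower number (0.69 log units; beyond the scatter) from compound 3 to compound 4; the limit leaves it open whether they differ. Compound 3, the starting point of the new step, is known only as a limit: the limit of > 8000 nM in this assay, at which 1 of the 4 values shown sits.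

The compounds shown cover one exchange on each of the two cores, so they say nothing yet about whether other groups on the amine nitrogen would carry over in the same way. From the compounds shown here alone, a plain phenyl or a benzyl group in that place remains open, as does the share of the methoxy group in the step.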